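From Phenyl to 4-Methylphenyl in Compound 3

The source may report more compounds than this note shows. Statements on the series, on what has been measured and on what is new or still open speak of the compounds shown alone.

In a physicochemical assay for solubility, read by HPLC, in phosphate buffer, measured as kinetic solubility, at pH 7.4 (on this read-out higher numbers stand for higher solubility and lower numbers for lower solubility), the three measured compounds read as follows
Compound 1 `CCC(=O)c1cc(-c2ccc(Cl)cc2)n(-c2ccc(S(C)(=O)=O)cc2)c1C` gives 4800 nM
Compound 2 `CCOC(=O)c1cc(-c2ccc(Cl)cc2)n(-c2ccc(S(N)(=O)=O)cc2)c1C` gives 4200 nM
Compound 3 `CCC(=O)c1cc(-c2ccccc2)n(-c2ccc(S(N)(=O)=O)cc2)c1C` gives 14100 nM

Compound 3 stands highest of the three, and the other two lie lower, beyond the scatter. Compound 4 `CCC(=O)c1cc(-c2ccc(C)cc2)n(-c2ccc(S(N)(=O)=O)cc2)c1C` differs from compound 3 by methyl in place of hydrogen on an aromatic carbon in the change from phenyl to 4-methylphenyl, methyl in place of hydrogen on an aromatic carbon. Among the measured compounds shown here, no measured pair differs in one place alone, so nothing sizes this change directly. The expected change in this assay is a modest fall, not clearly beyond the scatter, estimated as a 1.8-fold lower number from compound 3 to compound 4 (0.25 log units; within the scatter) in size. That expectation rests on compound 3, whose 14100 nM is the top of the set. Compound 4 is estimated at 8000 nM with 3500 nM to 15000 nM as the expected range.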

Compound 4, solubility: 1000 nM
Beside the measured number, compound 4's estimate is 8.0-fold (0.90 log units) above it; the measured number lies below the stated range.
By their numbers in this assay, from the lowest: compound 4; then compounds 2 and 1 (each within the scatter of the next); then compound 3.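

In this assay, among the compounds shown here, the change from phenyl to 4-methylphenyl gives a 14-fold lower number from compound 3 to compound 4 (1.15 log units; beyond the scatter) and is the first step in the set that differs in one place alone. It shows that this aromatic carbon, para to a large group, is not indifferent to a single added methyl, since that one heavy atom moves the number well beyond the scatter. No evidence given here accounts for this fall.

From the compounds shown here alone, it remains open whether methoxy, an amine or a carboxylic acid on the same carbon would lower the number as methyl does. Going by these compounds, it also remains open whether the same step would be as large on a core carrying another group elsewhere.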